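The source may hold more compounds than are shown below. What is called first, only, known or untested is meant among the compounds shown, and "the series" means these compounds.

In an assay on HEK293 cells for displacement of a labelled ligand from Melanocortin receptor 4 (Homo sapiens) (a lower number here means a stronger inhibitor, a higher number a weaker inhibitor), three compounds that share one core have been measured. Compound 1 `CC(C)C[C@H](N)c1cc(C(F)(F)F)ccc1N1CCN(C(=O)CCc2ccc(O)cc2)CC1` gives only a limit in this assay, > 10000 nM, and no number. Compound 2 `COc1ccc(CCC(=O)N2CCN(c3ccc(C(F)(F)F)cc3[C@@H](N)CC(C)C)CC2)cc1` gives 350 nM in this assay, and compound 3 `COc1cc(OC)c(OC)cc1CCC(=O)N1CCN(c2ccc(C(F)(F)F)cc2[C@@H](N)CC(C)C)CC1` gives 6100 nM. Compound 3 therefore stands highest of the two numbers shown, its nearest neighbour being compound 2 with a step of a 17-fold higher number from compound 2 to compound 3 (1.24 log units; beyond the scatter). From the limit of compound 1 the limit of > 10000 nM in this assay, at which 1 of the 3 values shown sits, the steps of an at least 28-fold lower number from compound 1 to compound 2 (1.45 log units; beyond the scatter) and an at least 1.6-fold lower number from compound 1 to compound 3 (0.21 log units; that floor lies within the scatter) give only floors, the first large, the second within the scatter.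

Compound 4 `CC(C)C[C@H](N)c1cc(C(F)(F)F)ccc1N1CCN(C(=O)CCc2cn(C)c3ccccc23)CC1` differs from compound 3 by one change: 1-methyl-1H-indol-3-yl in place of 2,4,5-trimethoxyphenyl on a saturated chain carbon, two bonds along the chain from a carbonyl carbon. The step from compound 2 to compound 3 is the one that bears directly on this place on the chain, and it was large; the floor from compound 1 to compound 2 shows that the same place can move the number strongly in the other direction. Compound 4 is therefore expected to move back toward the number of compound 2, with a step of about a 10-fold lower number from compound 3 to compound 4 (1.01 log units; beyond the scatter). For compound 4 the estimated value in this assay is 600 nM, between 100 nM and 3500 nM.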

Compound 4, inhibition constant: 3000 nM
For compound 4 the middle estimate is 5.0-fold (0.70 log units) below the measured one; the range from low to high includes it.
By their numbers in this assay, from the lowest: compound 2; then compound 4; then compound 3. At a limit, above all of these: compound 1.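

Putting 1-methyl-1H-indol-3-yl in place of 2,4,5-trimethoxyphenyl on this saturated chain carbon gives a 2.0-fold lower number from compound 3 to compound 4 (0.31 log units; beyond the scatter) in this assay, so this place also accepts a group with a five-membered aromatic ring containing a hetero atom, and the number does not depend on a substituted phenyl alone. The same group still gives an 8.6-fold higher number from compound 2 to compound 4 (0.93 log units; beyond the scatter), which leaves 4-methoxyphenyl with the lowest number among the groups shown here and shows that the indole recovers only a small part of the large step between the two methoxy-bearing phenyl groups. The remaining step, an at least 3.3-fold lower number from compound 1 to compound 4 (0.52 log units; beyond the scatter), is only a floor, because compound 1 gives a limit and no number: the limit of > 10000 nM in this assay, at which 1 of the 4 values shown sits.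

The compounds shown leave open whether the methyl on the indole nitrogen contributes to the number, which a hydrogen in its place would test, and whether an unsubstituted phenyl would stand closer to 4-methoxyphenyl. They also leave open how a longer chain between the carbonyl and the aromatic ring, or a carboxylic acid on that ring, would change the number at this place.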